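Methyl for hydrogen on the phenyl of compound 2

The source may hold more compounds than are shown below. What is called first, only, known or untested is meant among the compounds shown, and "the series" means these compounds.

Among the compounds with values here, compound 2 `COn1c(-c2ccccc2)c(C=O)c2cc(C#N)c(C#N)cc21` gives 522 nM in an assay on isolated protein for inhibition of Amine oxidase [flavin-containing] A (Homo sapiens), read by fluorescence and spectrophotometry, with a stated time of 20 min (a higher number here means a weaker inhibitor, a lower number a stronger inhibitor), and stands lowest of the two numbers measured so far. Compound 1 `N#Cc1cc2cc(-c3cccs3)n(O)c2cc1C#N` gives 11100 nM in this assay, and the gap between compound 1 and compound 2 is beyond the scatter. Compound 3 `COn1c(-c2ccc(C)cc2)c(C=O)c2cc(C#N)c(C#N)cc21` is not yet measured. It differs from compound 2 by methyl in place of hydrogen on an aromatic carbon, on an aromatic carbon of a six-membered aromatic ring of carbon only, para to a large group; the same difference read one bond further out is phenyl to 4-methylphenyl. Within the data shown here, no pair of measured compounds differing in one place exists in this set, so the size of such a step has no precedent here. A small step in this assay is expected for compound 3, with no direction beyond the scatter. Compound 3 is estimated at 420 nM, between 150 nM and 1200 nM. The expected step of a 1.2-fold lower number from compound 2 to compound 3 (0.09 log units; within the scatter) lies within the scatter.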

Compound 3, half-maximal inhibitory concentration: 405 nM
The estimate for compound 3 lay 1.0-fold (0.02 log units) above the measured number, within the range that was stated.
By their numbers in this assay, from the lowest: compounds 3 and 2 (each within the scatter of the next); then compound 1.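

Within the data shown here, the step of a 1.3-fold lower number from compound 2 to compound 3 (0.11 log units; within the scatter) in this assay is the first between compounds that differ in one place. It shows that methyl in place of hydrogen on the phenyl, para to a large group, is accommodated without a shift that can be told from the scatter. On this single step, the position accepts one added carbon, but the result gives no direction for the change. No measurement here bears on why the step is this small.

Going by these compounds, whether an ethyl, an amine or a carboxylic acid at the same position would move the number beyond the scatter remains open. Also open, on these data alone, is how much of the gap to compound 1 belongs to any single part, as compound 1 differs from compound 2 in more than one place.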